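Changing One Halogenated Aryl Group on a Shared Core

This account rests on a few compounds, and the source may have more. Where it says the series, first, only, none or still open, it means among the compounds named here.

Within the data shown here, compound 1 `COc1cccc(/C=C2\CCC/C(=C\c3cccc(Br)c3)C2=O)c1OC` gives in a functional assay on HT-1080 cells (Homo sapiens) for cytotoxicity, read by MTT assay, with a stated time of 72 h (on this read-out lower numbers stand for stronger inhibition and higher numbers for weaker inhibition), a value of 12200 nM, the lowest of the two numbers measured so far. Compound 2 `COc1ccccc1/C=C1\CCC/C(=C\c2cccc(OC)c2OC)C1=O` gives in this assay 14100 nM; the step of a 1.2-fold higher number from compound 1 to compound 2 (0.06 log units; within the scatter) lies within the scatter, so the two compounds cannot be put in order. Compound 3 `COc1cccc(/C=C2\CCC/C(=C\c3ccc(Cl)cc3Cl)C2=O)c1OC` has not yet been measured in this assay. It differs from compound 1 by 2,4-dichlorophenyl in place of 3-bromophenyl on a double-bonded chain carbon bound to a double-bonded ring carbon. Among the measured compounds shown here, only one measured step bears on this change, the step of a 1.2-fold higher number from compound 1 to compound 2 (0.06 log units; within the scatter), which likewise exchanges the aryl group on the double-bonded chain carbon and hardly moves the number. Compound 3 is therefore expected to show a 1.1-fold lower number from compound 1 to compound 3 (0.04 log units; within the scatter), with no direction beyond the scatter. Compound 3 is expected to give 11000 nM in this assay, within a range of 5000 nM to 25000 nM.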

Compound 3, half-maximal inhibitory concentration: > 20000 nM
Compound 3: no number, only a limit (the forecaster's own chance of this, stated with the estimate: 5%); middle value at least 1.8-fold (0.25 log units) from the limit.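

Among these compounds, at this position on a double-bonded chain carbon bound to a double-bonded ring carbon, 2,4-dichlorophenyl is the first group to take the read-out to a limit, and compound 3 gives > 20000 nM in this assay, which is a limit and not a number: the limit of > 20000 nM in this assay, at which 1 of the 3 values shown sits. The change from 3-bromophenyl gives an at least 1.6-fold higher number from compound 1 to compound 3 (0.21 log units; that floor lies within the scatter), and the change from 2-methoxyphenyl gives an at least 1.4-fold higher number from compound 2 to compound 3 (0.15 log units; that floor lies within the scatter). These steps can point only upward, unlike the earlier step between compound 1 and compound 2, but neither floor is shown to pass the scatter.

Going by these compounds, how far the true value of compound 3 lies from the other two values remains open. Also open, on these data alone, is how this position would respond to an amine, a carboxylic acid or a longer chain in place of the aryl group.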